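Cytotoxicity in the shared-core series: removing the amino group

This account rests on a few compounds, and the source may have more. Where it says the series, first, only, none or still open, it means among the compounds named here.

Measured so far:
compound 1 `O=c1ccn(CCCCCOc2ccc([N+](=O)[O-])cc2)c(=O)[nH]1`: 20000 nM
compound 2 `Nc1ccc(OCCCCCn2ccc(=O)[nH]c2=O)cc1`: > 100000 nM

In an ADME assay on HEL cells (Homo sapiens) for cytotoxicity, read by microscopy (on this read-out lower numbers stand for higher toxicity in this test and higher numbers for lower toxicity in this test), compound 1 gives 20000 nM. For compound 2 the assay reports only a limit, > 100000 nM, so compound 2 stands at the edge of the numbers shown. Among the compounds with values here, the single measured step, an at least 5.0-fold higher number from compound 1 to compound 2 (0.69 log units; beyond the scatter), is bounded by the limit of > 100000 nM in this assay, at which 1 of the 2 values shown sits. Compound 3 `O=c1ccn(CCCCCOc2ccccc2)c(=O)[nH]1` differs from compound 2 by hydrogen in place of amino on an aromatic carbon. Within the data shown here, no measured step removes a group outright, so the nitro-to-amino step is only a loose guide; compound 3 is expected to fall between the two measured values, with an at least 2.0-fold lower number from compound 2 to compound 3 (0.30 log units; that floor lies within the scatter). Compound 3 is estimated at 50000 nM (range 20000 nM to 100000 nM), and a limit is possible.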

Compound 3, minimum cytotoxic concentration: > 100000 nM
Compound 3 was reported as a limit (the forecaster's own chance of this, stated with the estimate: 40%); middle value at least 2.0-fold (0.30 log units) from the limit.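

In this assay, hydrogen in place of nitro on the aromatic carbon gives an at least 5.0-fold higher number from compound 1 to compound 3 (0.69 log units; beyond the scatter), so the unsubstituted phenyl behaves like the amino compound rather than the nitro compound. Compound 3 is reported only as a limit, > 100000 nM. The step between compound 2 and compound 3 cannot be read, and amino and hydrogen cannot be ranked: the limit of > 100000 nM in this assay, at which 2 of the 3 values shown sit.

As far as these compounds go, how far compound 2 and compound 3 lie beyond the limit stays open. Also open, from the compounds shown here alone, is how a methoxy group or a chlorine at this place, or a longer chain, would read.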